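The compounds below may be only part of what the source reports. "The series", "measured", "known", "first", "only" and "open" are said of these compounds alone.

Measured so far:
- compound 1 (`COc1ccc(C(=O)c2cc(OC)c(OC)c(OC)c2)c(NC(=O)CO)c1`) gives 70 nM
- compound 2 (`C=C(c1ccc2c(c1)C=CC(C)(C)O2)c1ccc(OC)cc1NC(=O)CO`) gives 100 nM

In a functional assay on HeLa cells (Homo sapiens) for antiproliferative activity, read by MTT assay, with a stated time of 48 h (on this read-out lower numbers stand for stronger inhibition and higher numbers for weaker inhibition), compound 2 (100 nM) lies within the usual scatter of compound 1 (70 nM), so these two numbers set no order.

Next in the series is compound 3 (`C=C(c1ccc2c(c1)C=CC(C)(C)O2)c1ccc(OC)cc1NC(=O)CN(C)C`), still unmeasured. It departs from compound 2 by one change: dimethylamino in place of hydroxy on a saturated chain carbon bound to a carbonyl carbon.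

Among the measured compounds shown here, the two measured compounds differ in more than one place, so the data hold no direct precedent for this change. A modest move towards weaker inhibition is expected in this assay, though with low confidence. The expected size is a 2.0-fold higher number from compound 2 to compound 3 (0.30 log units; within the scatter), and this estimate may not lie far beyond the scatter.

Compound 3 is estimated at 200 nM (expected range 40 nM to 1000 nM).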

Compound 3, half-maximal inhibitory concentration: 640 nM
Beside the measured number, compound 3's estimate is 3.2-fold (0.51 log units) below it; the measured number falls inside the stated range.
By their numbers in this assay, from the lowest: compounds 1 and 2 (each within the scatter of the next); then compound 3.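

In this assay, among the compounds shown here, this position proves sensitive to substitution: dimethylamino in place of hydroxy on a saturated chain carbon bound to a carbonyl carbon gives a 6.4-fold higher number from compound 2 to compound 3 (0.81 log units; beyond the scatter), the first single-place change that can be read. The change takes the count of hydrogen-bond donors from 1 to 0 and adds heavy atoms at once, so this one step cannot tell which of the two matters. No measurement on hand bears on the reason for the step.

From the compounds shown here alone, whether a methoxy group, a primary amine, a carboxylic acid or a longer chain ending in hydroxy would hold the number of compound 2 at this position remains open. Also open, going by these compounds, is whether the same change would give a similar step on the core of compound 1.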